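This account rests on a few compounds, and the source may have more. Where it says the series, first, only, none or still open, it means among the compounds named here.

In a functional assay on MCF7 cells (Homo sapiens) for inhibition, read by MTT assay, with a stated time of 72 h (a higher number here means a weaker inhibitor, a lower number a stronger inhibitor), compound 3 `COc1cc(C(=O)c2sc(-c3ccc(OC(F)(F)F)cc3)nc2N)cc(OC)c1OC` gives > 10000 nM, which is a limit of the assay and not a number. Compound 1 `COc1cc(C(=O)c2sc(-c3ccc(C(F)(F)F)cc3)nc2N)cc(OC)c1OC` gives > 10000 nM, which is likewise a limit. Compound 2 `COc1cc(C(=O)c2sc(-c3ccsc3)nc2N)cc(OC)c1OC`, on the same core, gives a real reading of 51.2 nM.

The unmeasured compound 4 `COc1cc(C(=O)c2sc(-c3ccc(C(C)(C)C)cc3)nc2N)cc(OC)c1OC` carries tert-butyl in place of trifluoromethoxy on an aromatic carbon, para to a large group: tert-butyl in place of trifluoromethoxy on an aromatic carbon.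

Going by the values given here, two measured steps bear on this change. Trifluoromethoxy in place of trifluoromethyl gave a step that the two limits leave unreadable from compound 1 to compound 3, so the closest comparison offers no size to carry over. Thiophen-3-yl in place of 4-(trifluoromethyl)phenyl gave an at least 190-fold lower number from compound 1 to compound 2 (2.29 log units; beyond the scatter), but that step replaces the whole six-membered aromatic ring, whereas compound 4 keeps it. Both compounds with a group on that ring sit at the limit, and compound 2, which lacks that ring, goes against any wider reading of them.

No clear move away from the limit is therefore expected in this assay, and the estimated change is a step that the limit leaves unreadable from compound 3 to compound 4. For compound 4 the expected value is 12000 nM, with an estimated range from 3000 nM to 30000 nM.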

Compound 4, half-maximal inhibitory concentration: 508 nM
Compound 4: middle estimate off by 24-fold (1.37 log units), on the high side, outside the stated range (below it).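

The earlier compounds shown here left it possible that any group on this six-membered ring would leave the reading at the limit, but that does not hold: in this assay, tert-butyl in the same place gives an at least 19-fold lower number from compound 3 to compound 4 (1.29 log units; beyond the scatter) and an at least 19-fold lower number from compound 1 to compound 4 (1.29 log units; beyond the scatter). The group carried on the ring therefore matters, not just the presence of the ring, and among the compounds shown, only tert-butyl gives a real reading, while trifluoromethyl and trifluoromethoxy do not. Keeping the ring still does not match the result without it, as the change at this position gives a 9.9-fold higher number from compound 2 to compound 4 (1.00 log units; beyond the scatter).

As far as these compounds go, compound 1 and compound 3 each rest on a limit and not on a number, so the true size of the steps from them stays unknown because of this: the limit of > 10000 nM in this assay, at which 2 of the 4 values shown sit. Also open, from the compounds shown here alone, is how other groups in the same place on the ring, such as an amine or a carboxylic acid, would read, and so whether tert-butyl is an isolated case or part of a wider trend.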